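Ring-nitrogen variation on the shared core

The source may hold more compounds than are shown below. What is called first, only, known or untested is meant among the compounds shown, and "the series" means these compounds.

Compound 3 `Cc1ccccc1NC(=S)N1CCc2c(sc(NC(=O)c3ccccc3Cl)c2C(N)=O)C1` sits in a functional assay on HeLa cells (Homo sapiens) for antiproliferative activity, with a stated time of 24 h (a higher number here means a weaker inhibitor, a lower number a stronger inhibitor), at > 50000 nM, which is a limit of the assay and not a number. Compound 1 `N#Cc1ccccc1CN1CCc2c(sc(NC(=O)c3ccccc3Cl)c2C(N)=O)C1` likewise stops at the limit > 50000 nM in this assay. Among the measured compounds shown here, compound 2 `NC(=O)c1c(NC(=O)c2ccccc2Cl)sc2c1CCN(Cc1ccc(Cl)cc1Cl)C2` gives 21100 nM in this assay, the only value in the set read directly as a number. All variation is on the amine nitrogen in a ring of the shared core, and the three measured steps all sit there: an at least 2.3-fold lower number from compound 1 to compound 2 (0.37 log units; beyond the scatter); an at least 2.3-fold higher number from compound 2 to compound 3 (0.37 log units; beyond the scatter); a step that the two limits leave unreadable from compound 1 to compound 3. Two of the three values rest on the same limit, (the limit of > 50000 nM in this assay, at which 2 of the 3 values shown sit), so the steps out of compound 1 and compound 3 are known only as bounds.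

Compound 4 `NC(=O)c1c(NC(=O)c2ccccc2Cl)sc2c1CCN(C(=O)Nc1c(Cl)cccc1Cl)C2` takes the step (a group of 11 heavy atoms (7 carbon, 1 nitrogen, 1 oxygen, 2 chlorine; one six-membered aromatic ring of carbon only) in place of a group of 10 heavy atoms (8 carbon, 1 nitrogen, 1 sulfur; one six-membered aromatic ring of carbon only), on an amine nitrogen in a ring). For the measured compounds named here, the nearest precedent is an at least 2.3-fold higher number from compound 2 to compound 3 (0.37 log units; beyond the scatter), in which the 2,4-dichlorophenyl-bearing compound 2 gave a number and compound 3 did not; compound 4 brings a dichlorophenyl ring back, now through a carbamoyl link. Expected is a step of an at least 1.6-fold lower number from compound 3 to compound 4 (0.22 log units; that floor lies within the scatter) in this assay, towards a lower number, its true size not readable while compound 3 stands at a limit. Compound 4 is thus estimated at 30000 nM, within 8000 nM to 120000 nM, with a fair chance that this assay again reports only a limit.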

Compound 4, half-maximal inhibitory concentration: 27200 nM
Compound 4: the middle estimate sits 1.1-fold (0.04 log units) above what was measured; the range from low to high includes it.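

Set against the benzyl-linked compound, the change gives a 1.3-fold higher number from compound 2 to compound 4 (0.11 log units; within the scatter) in this assay, so (2,6-dichlorophenyl)carbamoyl and 2,4-dichlorobenzyl cannot be told apart on this amine nitrogen in a ring. Among the compounds shown here, compound 2 and compound 4 both carry a dichlorophenyl ring and are the only compounds here that give numbers, whether the link is a saturated chain carbon or a carbamoyl; none of the four compounds goes against this, though four compounds carry the pattern no further than themselves. The other two steps, an at least 1.8-fold lower number from compound 3 to compound 4 (0.26 log units; that floor lies within the scatter) and an at least 1.8-fold lower number from compound 1 to compound 4 (0.26 log units; that floor lies within the scatter), have floors within the scatter and stay bounds only, because their starting values are limits of the assay and not numbers: the limit of > 50000 nM in this assay, at which 2 of the 4 values shown sit.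

Compound 2 and compound 4 differ in both the link and the placing of the chlorines, so the contribution of each stays unseparated. Open as well is what a plain phenylcarbamoyl group, a longer chain such as 2-phenylethyl, or an amine or carboxylic acid on the aromatic ring would give on this nitrogen, and whether any such group reaches far lower numbers.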